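A few compounds are considered here, and "the series" means these few. Any claim that something is new, unique, unknown or untested is made for them only; others in the source may bear on it.

Working notes on the series. Among the measured compounds shown here, compound 1 `CCCCNC(=O)[C@@H](NC(=O)c1cccc(Cn2ccnc2)c1)[C@@H](C)CC` is the only member with a number: in an assay on HEK293 cells for displacement of a labelled ligand from Type-2 angiotensin II receptor (Homo sapiens), tested at 10 uM (on this read-out lower numbers stand for a weaker effect and higher numbers for a stronger effect at the one concentration tested), compound 1 gives 3%, which is the sole value in the set. Compound 2 `CCCCCS(=O)(=O)NNC(=O)[C@@H](NC(=O)c1cccc(Cn2ccnc2)c1)[C@@H](C)CC` belongs to the same series, but in this assay compound 2 gives "not determined" (no result reported), that is, no result reported, so compound 1 stands alone without any comparison. Compound 3 `CC[C@H](C)[C@H](NC(=O)c1cccc(Cn2ccnc2)c1)C(=O)NO` is the next compound, not yet measured in this assay. Its difference from compound 1 is hydroxy in place of butyl on an amide-type nitrogen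

The shared core and the rest of the chain are unchanged, so the whole question is what hydroxy in place of butyl on the amide-type nitrogen does. For the measured compounds named here, with no step between measured compounds available, the expected change a number 2 percentage points higher from compound 1 to compound 3 (within the scatter) is set to lie within the scatter of repeated measurements, with no direction claimed. For compound 3 the estimate in this assay is therefore 5%, with a range from 0% to 20%.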

Compound 3, a percentage reported as inhibition, at one concentration (the size of the read-out at that concentration, not a potency): 4%
Estimate against measurement, compound 3: 1 percentage points above; the measured number falls inside the stated range.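

At this position, this assay now gives a first readable step, a number 1 percentage points higher from compound 1 to compound 3 (within the scatter), for hydroxy in place of butyl on the amide-type nitrogen. Butyl carries no hydrogen-bond donor or acceptor and hydroxy carries one of each, yet this exchange leaves the two compounds within the scatter of each other on this read-out, so the change shows no measurable effect here. No available evidence bears on this result.

Steps involving compound 2 cannot be read, so the sulfonyl hydrazide side of the series stays without a comparison. Going by these compounds, what an amine, a carboxylic acid or a longer chain on the amide-type nitrogen would do remains open, as does whether any change at this position can move the read-out beyond the scatter.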